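Oral exposure in the series: methoxy for methyl on pyridine

The source may report more compounds than this note shows. Statements on the series, on what has been measured and on what is new or still open speak of the compounds shown alone.

Measured compounds and numbers:
- compound 1, `Cc1cn2c(-c3cn[nH]c3)cnc2c(Nc2cc(Cc3ccccn3)ns2)n1`: 6880 ng.h/mL
- compound 2, `Cc1cccc(Cc2cc(Nc3nc(C)cn4c(-c5cn[nH]c5)cnc34)sn2)n1`: 3100 ng.h/mL

Going by the values given here, in an ADME assay on the whole organism for pharmacokinetics, with Rattus norvegicus as the target, with a stated time of 6 h, at a dose of 10 mg/kg by the oral route (a higher number here means more compound in the circulation at the dose given, a lower number less compound in the circulation), compound 2 stands lowest of the two numbers so far; the one step that reaches it is a 2.2-fold lower number from compound 1 to compound 2 (0.35 log units; beyond the scatter), and that gap is beyond the scatter. Compound 3 is `COc1cccc(Cc2cc(Nc3nc(C)cn4c(-c5cn[nH]c5)cnc34)sn2)n1`. The change from compound 2 is methoxy in place of methyl on an aromatic carbon. Among the compounds with values here, no measured step exchanges one small group for another at this position; the only step known, from compound 1 to compound 2, concerns adding a group there, not replacing it, so it gives only a loose guide to the size of change such a swap can bring in this assay. With that single modest precedent, the expectation for compound 3 is a step of a 1.0-fold lower number from compound 2 to compound 3 (0.01 log units; within the scatter), that is, no movement beyond the scatter in either direction. Compound 3 is therefore estimated at 3000 ng.h/mL, with a range from 1200 ng.h/mL to 7500 ng.h/mL.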

Compound 3, area under the concentration-time curve: 2300 ng.h/mL
Compound 3: middle estimate off by 1.3-fold (0.12 log units), on the high side; measured number inside the range.
By their numbers in this assay, from the lowest: compounds 3 and 2 (each within the scatter of the next); then compound 1.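

In this assay, the exchange of methyl for methoxy on the aromatic carbon next to the ring nitrogen gives a 1.3-fold lower number from compound 2 to compound 3 (0.13 log units; within the scatter), so these two groups cannot be told apart at this position. Against the unsubstituted compound, methoxy gives a 3.0-fold lower number from compound 1 to compound 3 (0.48 log units; beyond the scatter) and methyl gives a 2.2-fold lower number from compound 1 to compound 2 (0.35 log units; beyond the scatter), so among these three compounds the gap goes with a group being present on this carbon rather than with which of the two it is, and no compound goes against this. The numbers come with no accompanying measurement that would account for them.

On these data alone, whether a fluorine, an amine or a longer chain such as ethoxy on this carbon would also stay apart from compound 1 remains open. With only methyl and methoxy shown here, the size of the group and the presence of the oxygen cannot be separated as influences on exposure.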